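Replacing morpholin-4-yl on the carbonyl carbon of compound 2

The source may report more compounds than this note shows. Statements on the series, on what has been measured and on what is new or still open speak of the compounds shown alone.

Measured so far in a physicochemical assay for solubility, measured as kinetic solubility, at pH 7.4; a higher number here means a more soluble compound, a lower number a less soluble compound:
compound 1 `COc1cc(N2CCC(C(=O)N3CCOCC3)CC2)ccc1Nc1nc(NC2CCCCC2)c2nc[nH]c2n1`: 19000 nM
compound 2 `COc1cc(N2CCC(CC(=O)N3CCOCC3)CC2)ccc1Nc1nc(NC2CCCCC2)c2nc[nH]c2n1`: 19000 nM

Level with compound 1, compound 2 stands at 19000 nM. The compound now awaiting measurement is compound 3 `COc1cc(N2CCC(CC(=O)N3CCC(N(C)C)C3)CC2)ccc1Nc1nc(NC2CCCCC2)c2nc[nH]c2n1`, which carries 3-(dimethylamino)pyrrolidin-1-yl in place of morpholin-4-yl on a carbonyl carbon.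

Within the data shown here, only one measured step exists, and it bears on this change only indirectly. In no change at the digits printed from compound 1 to compound 2 (within the scatter), ((morpholin-4-yl)carbonyl)methyl stands in place of (morpholin-4-yl)carbonyl on a saturated ring carbon, so morpholin-4-yl is present on both sides of that step. Among the measured compounds shown here, no measured compound shows what exchanging morpholin-4-yl itself does in this assay, so the flat step cannot be carried over to the new change. The expectation therefore rests on the structural change alone, and it is an uncertain one. An upward move beyond the scatter is expected, with the size estimated as a 2.9-fold higher number from compound 2 to compound 3 (0.46 log units; beyond the scatter). The range is kept wide, and its lower end allows for no move at all. For compound 3 the expected value is 55000 nM, with an estimated range from 19000 nM to 150000 nM.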

Compound 3, solubility: 75000 nM
Compound 3: middle estimate off by 1.4-fold (0.13 log units), on the low side, within the range that was stated.
By their numbers in this assay, from the lowest: compounds 1 and 2 (each within the scatter of the next); then compound 3.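

In this assay, the exchange of morpholin-4-yl for 3-(dimethylamino)pyrrolidin-1-yl on a carbonyl carbon gives the first measured move at this position, a 3.9-fold higher number from compound 2 to compound 3 (0.60 log units; beyond the scatter) and so differs from the earlier step, which kept morpholin-4-yl and showed no change at the digits printed from compound 1 to compound 2 (within the scatter) in the same read-out. Set against compound 1, the replacement of (morpholin-4-yl)carbonyl on a saturated ring carbon by ((3-(dimethylamino)pyrrolidin-1-yl)carbonyl)methyl shows a 3.9-fold higher number from compound 1 to compound 3 (0.60 log units; beyond the scatter) and thus matches the step from the morpholin-4-yl compound with the same chain, so of the two exchanges shown, only the one that removes morpholin-4-yl comes with a move beyond the scatter. Nothing among the data gives a measured reason for this rise.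

Still open, from the compounds shown here alone, is whether the rise goes with the dimethylamino group or with the five-membered ring, since compound 3 brings both at once, and a plain pyrrolidin-1-yl or a 4-methylpiperazin-1-yl on the same carbonyl carbon would separate the two. Also open, going by these compounds, is whether 3-(dimethylamino)pyrrolidin-1-yl would give a step of like size on the carbonyl attached directly to the saturated ring carbon, as in compound 1.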